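This account rests on a few compounds, and the source may have more. Where it says the series, first, only, none or still open, it means among the compounds named here.

Among the measured compounds shown here, in a functional assay on HepG2 cells (Homo sapiens) for inhibition, read by MTT assay, with a stated time of 72 h (on this read-out lower numbers stand for stronger inhibition and higher numbers for weaker inhibition), the series so far holds two measured compounds. Compound 1 `COc1ccc(-n2cc(COc3cccc(NC(=O)Nc4ccc(Cl)c(C(F)(F)F)c4)c3)nn2)cc1` gives 4680 nM in this assay, and compound 2 `O=C(Nc1cccc(OCc2cn(-c3cccc(Cl)c3)nn2)c1)Nc1ccc(Cl)c(C(F)(F)F)c1` gives 2020 nM. For the measured compounds named here, the single step between them, a 2.3-fold lower number from compound 1 to compound 2 (0.36 log units; beyond the scatter), put 3-chlorophenyl in place of 4-methoxyphenyl on an aromatic nitrogen. On the two numbers shown, compound 2 stands lowest; its only neighbour, compound 1, sits at the higher value quoted.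

Compound 3 `O=C(Nc1cccc(OCc2cn(-c3ccc(I)cc3)nn2)c1)Nc1ccc(Cl)c(C(F)(F)F)c1` has not yet been measured in this assay. It differs from compound 2 in one place: 4-iodophenyl in place of 3-chlorophenyl on an aromatic nitrogen. Going by the values given here, the one measured step bears on this change only loosely, since a 2.3-fold lower number from compound 1 to compound 2 (0.36 log units; beyond the scatter) exchanged a group at the same aromatic nitrogen, but it traded 4-methoxyphenyl for 3-chlorophenyl, whereas here 3-chlorophenyl gives way to 4-iodophenyl. Among the compounds with values here, no measured pair shows one such phenyl exchanged for another. The step is therefore expected to be small and without a clear direction beyond the scatter, a 1.1-fold higher number from compound 2 to compound 3 (0.04 log units; within the scatter). Compound 3 is estimated at 2200 nM, with a range from 700 nM to 7000 nM.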

Compound 3, half-maximal inhibitory concentration: 2690 nM
The estimate for compound 3 lay 1.2-fold (0.09 log units) below the measured number; the measured number falls inside the stated range.
By their numbers in this assay, from the lowest: compounds 2, 3 and 1 (each within the scatter of the next, the first and the last beyond it).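

In this assay, among the compounds shown here, this is the first pair in which one halogen-bearing phenyl replaces another on the aromatic nitrogen, and exchanging 3-chlorophenyl for 4-iodophenyl gives a 1.3-fold higher number from compound 2 to compound 3 (0.12 log units; within the scatter), so the two groups cannot be told apart at this position. The 4-iodophenyl group also cannot be separated from 4-methoxyphenyl at the same place, as iodo in place of methoxy on an aromatic carbon gives a 1.7-fold lower number from compound 1 to compound 3 (0.24 log units; within the scatter), whereas only a 2.3-fold lower number from compound 1 to compound 2 (0.36 log units; beyond the scatter) lies beyond the scatter. The three substituted phenyl groups therefore fall close together here, and no measurement offered here accounts for the steps among them.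

The step to compound 3 changes both the halogen and its place on the phenyl ring, and the compounds shown cannot separate these two changes. From the compounds shown here alone, how this read-out would respond to an amine or a carboxylic acid on that phenyl ring, or to a longer chain in place of the ring on the aromatic nitrogen, also remains open.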